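Carbamate Replaces the Thiophene Amide Chain

The compounds below may be only part of what the source reports. "The series", "measured", "known", "first", "only" and "open" are said of these compounds alone.

Three measured compounds share one core and differ only in the group carried on the oxygen on the aromatic ring. Compound 1 `CC(C)=CCC1Cc2c(OCCCNS(=O)(=O)c3ccc(Cl)cc3)cc(=O)n(CCCO)c2CC1(C)C` carries a chain ending in a (4-chlorophenyl)sulfonyl amine; in a functional assay on PANC-1 cells (Homo sapiens) for inhibition, read by MTT assay, with a stated time of 24 h, tested at 10 uM (a higher number here means more inhibition at the concentration tested (going by the name of the read-out), a lower number less inhibition), compound 1 gives 24.7%. Compound 2 `CC(C)=CCC1Cc2c(OCCCNC(=O)c3cccs3)cc(=O)n(CCCO)c2CC1(C)C` carries the (thiophen-2-yl)carbonyl analogue, and in this assay compound 2 gives 33.6%. Compound 3 `CC(C)=CCC1Cc2c(OCCCOc3ccc([N+](=O)[O-])cc3)cc(=O)n(CCCO)c2CC1(C)C` carries a 4-nitrophenoxy terminus, and in this assay compound 3 gives 47.5%. On the numbers shown compound 2 stands second highest of the three: a number 8.9 percentage points higher from compound 1 to compound 2 (within the scatter), while a number 13.9 percentage points higher from compound 2 to compound 3 (beyond the scatter) and a number 22.8 percentage points higher from compound 1 to compound 3 (beyond the scatter).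

Compound 4 `CC(C)=CCC1Cc2c(OC(=O)Nc3ccc(Cl)cc3)cc(=O)n(CCCO)c2CC1(C)C` is not yet measured. Its change from compound 2 is (4-chlorophenyl)carbamoyl in place of 3-(((thiophen-2-yl)carbonyl)amino)propyl on an oxygen on an aromatic ring. Among the compounds with values here, no measured step covers this kind of change: the steps known so far all swap the terminus of the three-carbon chain, and they ranged from within the scatter to a modest rise. The change to compound 4 removes the chain altogether, so those steps give only loose guidance. The account therefore expects in this assay no step beyond the scatter, a number 3.6 percentage points lower from compound 2 to compound 4 (within the scatter). For compound 4 the estimate is 30%, expected to fall within a range from 14% to 50%.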

Compound 4, a percentage reported as inhibition, at one concentration (the size of the read-out at that concentration, not a potency): 49.8%
Estimate against measurement, compound 4: 19.8 percentage points below; the range from low to high includes it.
By their numbers in this assay, from the lowest: compounds 1 and 2 (each within the scatter of the next); then compounds 3 and 4 (each within the scatter of the next).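

Putting (4-chlorophenyl)carbamoyl in place of 3-(((thiophen-2-yl)carbonyl)amino)propyl on the oxygen on an aromatic ring gives, in this assay, a number 16.2 percentage points higher from compound 2 to compound 4 (beyond the scatter), so at this position the whole propyl chain can go without the number falling. The earlier steps shown here changed only the end of that chain, whereas compound 4 shows that a group without it can reach the level of the best chain compound: compound 3 gives 47.5% and compound 4 gives 49.8%, values within the scatter of each other. Nothing shown here offers an explanation for this rise.

The compounds shown leave open whether the rise belongs to the carbamoyl link or to the 4-chlorophenyl group, since no compound separates the two. A carbamoyl group bearing an unsubstituted phenyl or a thiophen-2-yl would address that question, and a carbamoyl group carrying a carboxylic acid or an amine on its ring would show how far this position accepts other groups.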